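Naphthalen-2-yl in place of 2-methyl-1,3-benzothiazol-5-yl

A few compounds are considered here, and "the series" means these few. Any claim that something is new, unique, unknown or untested is made for them only; others in the source may bear on it.

In a functional assay on MCF7 cells (Homo sapiens) for antiproliferative activity, read by CellTiter-Glo, with a stated time of 5 days (on this read-out lower numbers stand for stronger inhibition and higher numbers for weaker inhibition), compound 1 (`CC/C(=C(/c1ccc(/C=C/C(=O)O)cc1)c1ccn2ccnc2c1)c1ccccc1`) gives > 500 nM, which is a limit and not a number. Compound 2 (`CC/C(=C(/c1ccc(/C=C/C(=O)O)cc1)c1ccc2sc(C)nc2c1)c1ccccc1`) gives > 500 nM, also a limit, so its position is known only as the limit of > 500 nM in this assay, at which 2 of the 2 values shown sit.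

The next change leads to compound 3 (`CC/C(=C(/c1ccc(/C=C/C(=O)O)cc1)c1ccc2ccccc2c1)c1ccccc1`): naphthalen-2-yl in place of 2-methyl-1,3-benzothiazol-5-yl on a double-bonded chain carbon bound to an aromatic carbon and a double-bonded chain carbon. The group on the double-bonded chain carbon bound to an aromatic carbon and a double-bonded chain carbon is exchanged again.

For the measured compounds named here, the only measured step at this place is a step that the two limits leave unreadable from compound 1 to compound 2. It offers no size or direction to carry over, so no readable shift is expected in this assay, and a further limit is the likeliest result.

The expected change is a step that the limit leaves unreadable from compound 2 to compound 3, an estimate with no firm direction. For compound 3 the estimated value is 600 nM, with an expected range of 150 nM to 2000 nM.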

Compound 3, half-maximal inhibitory concentration: 180 nM
Estimate against measurement, compound 3: 3.3-fold (0.52 log units) above, and the stated range covers the measured number.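

In this assay, naphthalen-2-yl in place of 2-methyl-1,3-benzothiazol-5-yl gives an at least 2.7-fold lower number from compound 2 to compound 3 (0.44 log units; beyond the scatter), a step of readable direction at this place, although its size is only a lower bound. The all-carbon group also compares favourably with the group of compound 1, with an at least 2.7-fold lower number from compound 1 to compound 3 (0.44 log units; beyond the scatter), while the step between the two compounds with ring hetero atoms cannot be read. Compound 3 is the only compound shown with a number rather than a limit: the limit of > 500 nM in this assay, at which 2 of the 3 values shown sit.

Going by these compounds, how far compound 1 and compound 2 lie beyond their limits remains open, as does which difference in the exchanged groups separates them from compound 3. Also open, on these data alone, is whether a quinolinyl group, or a naphthalen-2-yl group carrying a methoxy group, keeps a readable value at this place.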